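Chloro on the aromatic ring of compound 2

The compounds below may be only part of what the source reports. "The series", "measured", "known", "first", "only" and "open" are said of these compounds alone.

Compound 1 `CC(C)[C@@H]1CC[C@@H](C)C[C@@]12N(C)C(=O)[C@@H]1[C@H]3C(=O)NC(=O)[C@H]3ON12` carries hydrogen on the amide-type nitrogen in the ring and in a functional assay, read by spectrophotometry, with a stated time of 2 h, tested at 2 mg/mL (on this read-out lower numbers stand for a weaker effect and higher numbers for a stronger effect at the one concentration tested), compound 1 gives 37.1%. Compound 2 `CC(C)[C@@H]1CC[C@@H](C)C[C@@]12N(C)C(=O)[C@@H]1[C@H]3C(=O)N(c4ccccc4)C(=O)[C@H]3ON12` has phenyl in place of that hydrogen; in this assay compound 2 gives 48.2%. Going by the values given here, the only step measured so far, a number 11.1 percentage points higher from compound 1 to compound 2 (beyond the scatter), was modest and beyond the scatter, so compound 2 stands highest of the two numbers, with compound 1 the nearest and lower.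

Compound 3 `CC(C)[C@@H]1CC[C@@H](C)C[C@@]12N(C)C(=O)[C@@H]1[C@H]3C(=O)N(c4ccc(Cl)cc4)C(=O)[C@H]3ON12` differs from compound 2 by chloro in place of hydrogen on an aromatic carbon. Among the compounds with values here, no measured step alters a substituent on the phenyl, so no step bears directly on this change; the phenyl-for-hydrogen step is a change of a different kind and gives no direction. The step of a number 1.8 percentage points higher from compound 2 to compound 3 (within the scatter) is therefore expected to remain within the scatter. Compound 3 is estimated at 50%, with a range from 35% to 65%.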

Compound 3, a percentage reported as activity, at one concentration (the size of the read-out at that concentration, not a potency): 56.4%
For compound 3 the middle estimate is 6.4 percentage points below the measured one, and the stated range covers the measured number.
By their numbers in this assay, from the lowest: compound 1; then compounds 2 and 3 (each within the scatter of the next).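

In this assay, going by these compounds alone, the step of a number 8.2 percentage points higher from compound 2 to compound 3 (within the scatter) is the only reading so far of a change on the aromatic ring, and it shows that chloro para to a large group leaves compound 3 not separable from compound 2. Against hydrogen on the amide-type nitrogen, the step of a number 19.3 percentage points higher from compound 1 to compound 3 (beyond the scatter) is modest, so compound 2 and compound 3 both stand apart from compound 1, and neither goes against this. No supporting data explain this result.

Open, as far as these compounds go, is whether an amine or a carboxylic acid on the same aromatic carbon would also stay within the scatter of compound 2, and whether chloro on another carbon of the ring would read alike. Also open, from the compounds shown here alone, is how a longer chain on the amide-type nitrogen would compare with phenyl.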